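Cytotoxicity notes on a pyrazole series: halogenated phenyl on ring nitrogen

This account rests on a few compounds, and the source may have more. Where it says the series, first, only, none or still open, it means among the compounds named here.

Measured so far:
- compound 1, `Cc1ccccc1-c1nn(-c2ccc(Br)cc2)cc1CNCCN1CCN(C)CC1` — 9600 nM
- compound 2, `CN1CCN(CCNCc2cn(-c3ccc(C(F)(F)F)cc3)nc2-c2ccc(C(F)(F)F)cc2)CC1` — 1500 nM
- compound 3, `Cc1ccccc1-c1nn(-c2ccc(F)cc2F)cc1CNCc1ccncc1` — limit only

All three compounds were run in an ADME assay on Huh-7 cells (Homo sapiens) for cytotoxicity; a lower number here means that less compound is tolerated, a higher number that more compound is tolerated. Compound 1 gives 9600 nM, which is the higher of the two actual numbers; compound 2 gives 1500 nM, and the gap between these two values lies beyond the usual scatter. Compound 3 reaches only the assay limit (the limit of > 20000 nM in this assay, at which 1 of the 3 values shown sits), recorded for compound 3 as > 20000 nM, so no number is known for it.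

The next compound to be read is compound 4, `Cc1ccccc1-c1nn(-c2ccccc2Cl)cc1CNCCN1CCN(C)CC1`. It differs from compound 1 in one place: 2-chlorophenyl in place of 4-bromophenyl on an aromatic nitrogen. Nothing else about the shared core or the remaining substituents changes between compound 1 and compound 4.

Among the compounds with values here, no pair of measured compounds in this set differs in only one place, so there is no measured step to lean on for this exchange. The data do not separate the contribution of the halogenated phenyl on the ring nitrogen from the other differences between compound 1 and compound 2. The expectation is therefore a step of modest size, and it is expected to stay within the usual scatter in either direction; the estimated step is a 1.3-fold higher number from compound 1 to compound 4 (0.10 log units; within the scatter). Compound 4 is expected to give about 12000 nM, with a plausible range from 4000 nM to 25000 nM, and some chance that only a limit is reported, as for compound 3.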

Compound 4, half-maximal cytotoxic concentration: > 20000 nM
Compound 4 gave a limit, no number; the forecaster's own chance of this, stated with the estimate: 25%; middle value at least 1.6-fold (0.22 log units) from the limit.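

Within the data shown here, this is the first step read at a single place: in this assay, 2-chlorophenyl in place of 4-bromophenyl on the aromatic nitrogen gives an at least 2.0-fold higher number from compound 1 to compound 4 (0.31 log units; beyond the scatter), with the 2-methylphenyl group and the large group unchanged. Among these compounds, the group on this nitrogen can thus shift the read-out beyond the scatter on its own, which the earlier compounds, differing in more than one place, could not show. Compound 4 gives only a limit, > 20000 nM, and the step has a lower bound but no upper end because the read-out stops at that limit: the limit of > 20000 nM in this assay, at which 2 of the 4 values shown sit.

On these data alone, whether the step belongs to the change of halogen or to the change of its place on the phenyl ring stays open, for this exchange alters both at once. Also open, as far as these compounds go, are how a 4-chlorophenyl group, an unsubstituted phenyl or a phenyl carrying an amine would read on this nitrogen, and whether the same exchange would give a similar step with a different large group on the shared core.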